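This account rests on a few compounds, and the source may have more. Where it says the series, first, only, none or still open, it means among the compounds named here.

Measured compounds:
- compound 1 `COc1ccccc1-c1cccc(COc2ccc([C@H](CC(=O)O)c3nccn3C)cc2)c1` — "not determined" (no result reported)
- compound 2 `Cc1cc(Cl)ccc1-c1cc(COc2ccc([C@H](CC(=O)O)c3nccn3C)cc2)ccc1C` — 9800 nM

Compound 1 `COc1ccccc1-c1cccc(COc2ccc([C@H](CC(=O)O)c3nccn3C)cc2)c1` carries no number at all, as its entry in an assay on CHO cells for agonist activity at Free fatty acid receptor 1 (Homo sapiens), read by luminescence, with a stated time of 20 s, in the presence of a further agent that is not named here (a higher number here means that more compound is needed for the effect, a lower number that less compound is needed), is "not determined" (no result reported), so nothing can be said about it beyond its structure. In this assay compound 2 `Cc1cc(Cl)ccc1-c1cc(COc2ccc([C@H](CC(=O)O)c3nccn3C)cc2)ccc1C` gives 9800 nM. For the measured compounds named here, this is the only value in the set, so compound 2 can be placed only relative to itself: a sizeable amount of compound is needed for the half-maximal effect, and there is no second measured compound to rank it against.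

The next compound keeps the shared core of compound 2 and changes one spot. Compound 3 `Cc1cc(Cl)ccc1-c1cccc(COc2ccc([C@H](CC(=O)O)c3nccn3C)cc2)c1` differs from compound 2 in that hydrogen in place of methyl on an aromatic carbon.

Going by the values given here, no pair of measured compounds shows a step of this kind, so the direction of the change is not known from the data. Losing a single carbon is a small change; the step from compound 2 to compound 3 in this assay is expected to be modest, a 1.4-fold lower number from compound 2 to compound 3 (0.15 log units; within the scatter), possibly no more than the scatter. Compound 3 is expected to give about 7000 nM, in a range from 2000 nM to 25000 nM.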

Compound 3, half-maximal effective concentration: 10000 nM
Compound 3: middle estimate off by 1.4-fold (0.15 log units), on the low side, within the range that was stated.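

In this assay, replacing the methyl on this aromatic carbon, ortho to a 4-chloro-2-methylphenyl group and para to a large group, with hydrogen gives a 1.0-fold higher number from compound 2 to compound 3 (0.01 log units; within the scatter). For the compounds shown here, this is the first reading of this position, and it shows that for this pair, removing one carbon from this spot leaves the two numbers indistinguishable, so the methyl makes no measurable difference here. Nothing in the available data offers an explanation for this result.

One swap at one position cannot show whether this carbon is insensitive to substitution in general, and a different group here, such as an amine, a methoxy group or a longer chain, could still give a clearly different number. On these data alone, the chlorine and the methyl on the 4-chloro-2-methylphenyl group remain the same in compound 2 and compound 3, so their contribution stays unknown, and compound 1, which has no reported number, cannot help to settle it.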